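Methoxy for fluoro on a two-ring aminopyrimidine core

The source may report more compounds than this note shows. Statements on the series, on what has been measured and on what is new or still open speak of the compounds shown alone.

Compound 1, with structure `Nc1ncc(-c2ccccc2)c(-c2ccccc2)n1`, is the parent of this small set. In an assay on CHO cells for displacement of a labelled ligand from adenosine receptor A1 (Homo sapiens), read by scintillation counting, with a stated time of 1 h, tested at 1 uM (on this read-out lower numbers stand for less inhibition and higher numbers for more inhibition at the one concentration tested (going by the name of the read-out)), compound 1 gives 32%. Compound 2, with structure `Nc1ncc(-c2ccc(F)cc2)c(-c2ccccc2)n1`, carries a fluoro in place of hydrogen on an aromatic carbon. In this assay compound 2 is reported only as a limit of the assay, > 80%, so its exact inhibition is not known. The step of a number at least 48 percentage points higher from compound 1 to compound 2 (beyond the scatter) is therefore at least large, with the true size hidden because of the limit of > 80% in this assay, at which 1 of the 2 values shown sits.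

Compound 3, with structure `COc1ccc(-c2cnc(N)nc2-c2ccccc2)cc1`, is not yet measured. It differs from compound 2 by methoxy in place of fluoro on an aromatic carbon. Going by the values given here, no measured step covers an exchange of one small substituent for another at this carbon; the only step known is the gain of fluoro over hydrogen from compound 1 to compound 2. Since compound 2 already sits at the limit, compound 3 may stay high or fall back part of the way toward compound 1. Compound 3 is estimated at 70%, within 45% to 90%. That expectation corresponds to an estimated step of a number at least 10 percentage points lower from compound 2 to compound 3 (that floor lies within the scatter).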

Compound 3, a percentage reported as inhibition, at one concentration (the size of the read-out at that concentration, not a potency): 56%
For compound 3 the middle estimate is 14 percentage points above the measured one; measured number inside the range.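

In this assay, this carbon, para to a large group, responds to which substituent it carries and not only to whether hydrogen has been replaced, so methoxy and fluoro are not interchangeable here. The step of a number at least 24 percentage points lower from compound 2 to compound 3 (beyond the scatter) gives only a minimum for the loss, and its true size stays hidden: the limit of > 80% in this assay, at which 1 of the 3 values shown sits. Methoxy still keeps an advantage over hydrogen, with the step of a number 24 percentage points higher from compound 1 to compound 3 (beyond the scatter), so both substituents shown at this carbon, fluoro and methoxy, give more inhibition than hydrogen at the one concentration tested.

Methoxy has more heavy atoms than fluoro and also brings a hydrogen-bond acceptor, and the compounds shown do not tell whether either difference lies behind the lower number. From the compounds shown here alone, how a chloro group, a hydroxyl, an amine or a longer chain such as ethoxy would behave at this carbon remains open, as does whether fluoro and methoxy would give the same ordering on the other aromatic ring of the shared core.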